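A few compounds are considered here, and "the series" means these few. Any claim that something is new, unique, unknown or untested is made for them only; others in the source may bear on it.

Of the compounds shown here, three with the same bicyclic core have been measured in an ADME assay, in phosphate buffer, at 28 degrees C, at pH 7.0; a higher number here means that the compound lasts longer, a lower number that the compound disappears faster. Compound 1 `CC(C)(C)C1=C(C(=O)O)N2C(=O)[C@H]([C@H](O)CCc3ccncc3)[C@H]2O1` gives 13.7 h, and compound 2 `CC(C)(C)C1=C(C(=O)O)N2C(=O)[C@H]([C@H](O)CCc3ccncc3)[C@@H]2O1` gives 7.1 h. These two have the same atoms and bonds and differ only in the configuration drawn at a saturated ring carbon, and the step of a 1.9-fold lower number from compound 1 to compound 2 (0.29 log units; within the scatter) stays within the scatter, which, given (the fact that compounds 1 and 2 differ only in the configuration as drawn), shows that this change of configuration alone does not move the half-life beyond repeat variation. Compound 3 `Cn1cc([C@H](O)[C@H]2C(=O)N3C(C(=O)O)=C(C(C)(C)C)O[C@H]23)nn1` gives 7 h; its number sits within the scatter of both compound 2 and compound 1, so no order among the three can be read from these values.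

Compound 4 `CC(C)(C)C1=C(C(=O)O)N2C(=O)[C@H]([C@@H](O)CCc3ccncc3)[C@H]2O1` has not yet been measured in this assay. It differs from compound 3 by 2-(pyridin-4-yl)ethyl in place of 1-methyl-1H-1,2,3-triazol-4-yl on a saturated chain carbon bound to an oxygen on a saturated carbon and a saturated ring carbon. Within the data shown here, no measured step among the three compounds changes this side chain, so the only step available, a 1.9-fold lower number from compound 1 to compound 2 (0.29 log units; within the scatter), bears on it indirectly: every variation seen so far, including a change of configuration, has stayed within the scatter, and the pyridinylethyl compounds 1 and 2 both lie within the scatter of compound 3. On that basis a step of a 1.3-fold higher number from compound 3 to compound 4 (0.11 log units; within the scatter) is expected, which is no change beyond the scatter. Compound 4 is therefore estimated at 9 h, with a range from 4.5 h to 18 h.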

Compound 4, half-life: 15.8 h
Estimate against measurement, compound 4: 1.8-fold (0.24 log units) below; low and high end bracket the measured number.
By their numbers in this assay, from the lowest: compounds 3, 2, 1 and 4 (each within the scatter of the next, the first and the last beyond it).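

In this assay, exchanging the 1-methyl-1H-1,2,3-triazol-4-yl group for the 2-(pyridin-4-yl)ethyl group gives (a 2.3-fold higher number from compound 3 to compound 4 (0.35 log units; beyond the scatter)), a modest change and the only listed step that alters this side chain. Changing the configuration at the saturated chain carbon alone gives (a 1.2-fold higher number from compound 1 to compound 4 (0.06 log units; within the scatter)), so that stereocentre by itself does not move the half-life beyond repeat variation: (the fact that compounds 1 and 4 differ only in the configuration as drawn). Among these compounds, changing the configuration at both the saturated chain carbon and the saturated ring carbon gives (a 2.2-fold higher number from compound 2 to compound 4 (0.35 log units; beyond the scatter)), so this pair of pyridinylethyl compounds separates beyond the scatter, though only modestly, while the single changes do not: (the fact that compounds 2 and 4 differ only in the configuration as drawn).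

The compounds shown leave open whether the step from the triazole side chain depends on the pyridin-4-yl ring or on the ethyl chain that carries it; a phenyl ring on the same ethyl chain, or a longer chain ending in the pyridin-4-yl ring, would begin to separate the two. They also leave open whether configuration matters in the same way when 1-methyl-1H-1,2,3-triazol-4-yl is the side chain.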